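The source may hold more compounds than are shown below. What is called first, only, known or untested is meant among the compounds shown, and "the series" means these compounds.

Compound 2, whose structure is `N[C@H]1CC[C@@H](Oc2ccc([C@H]3CC[C@]4(CC3)OOC3(O4)C4CC5CC(C4)CC3C5)cc2)CC1`, is one of three compounds built on a shared core that differ only in the group carried on an oxygen on an aromatic ring. In an ADME assay on microsomes from liver (Homo sapiens) for metabolic stability, read by LC-MS, tested at 1 uM (on this read-out higher numbers stand for fast clearance and lower numbers for slow clearance), compound 2 gives < 7 mL.min-1.g-1, which is a limit of the assay rather than a measured number. Compound 1, with structure `NCCOc1ccc([C@H]2CC[C@]3(CC2)OOC2(O3)C3CC4CC(C3)CC2C4)cc1`, gives < 7 mL.min-1.g-1 in this assay, also a limit. Compound 3, with structure `c1cc([C@H]2CC[C@]3(CC2)OOC2(O3)C3CC4CC(C3)CC2C4)ccc1OCCC1CCNCC1`, gives < 7 mL.min-1.g-1 in this assay, again a limit. Among the measured compounds shown here, all three values share (the limit of < 7 mL.min-1.g-1 in this assay, at which 3 of the 3 values shown sit), so the steps between them, a step that the two limits leave unreadable from compound 1 to compound 2, a step that the two limits leave unreadable from compound 1 to compound 3 and a step that the two limits leave unreadable from compound 2 to compound 3, cannot be read for size; they show only that the three compounds all clear slowly in this assay.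

Compound 4, with structure `CC(C)(CN)Oc1ccc([C@H]2CC[C@]3(CC2)OOC2(O3)C3CC4CC(C3)CC2C4)cc1`, has not yet been measured. It differs from compound 2 in one place: 1-(aminomethyl)-1-methylethyl in place of 4-aminocyclohexyl on an oxygen on an aromatic ring. For the measured compounds named here, no measured step with a readable size bears on this change; what the three neighbours do show is that three different groups on that oxygen all leave clearance at the limit. On that basis compound 4 is expected to behave likewise, with an estimated intrinsic clearance of 5 mL.min-1.g-1, in a range from 2 mL.min-1.g-1 to 12 mL.min-1.g-1. The estimated step that the limit leaves unreadable from compound 2 to compound 4 is expected to be nothing beyond the scatter, and the assay is expected most likely to report a limit again.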

Compound 4, intrinsic clearance in microsomes: < 7 mL.min-1.g-1
Compound 4 was reported as a limit; the forecaster's own chance of this, stated with the estimate: 75%; the middle value is on the limit's open side.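

Compound 4 sits at a limit of the assay, just as compound 1, compound 2 and compound 3 do, so none of the steps joining compound 4 to them can be read for size: the limit of < 7 mL.min-1.g-1 in this assay, at which 4 of the 4 values shown sit. On these data alone, what remains open is the actual clearance of each compound in this assay, and whether any group on that oxygen would give a readable number.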